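Adding a bromo group to compound 1

The compounds below may be only part of what the source reports. "The series", "measured", "known", "first", "only" and "open" are said of these compounds alone.

In a functional assay on HeLa cells (Homo sapiens) for antiproliferative activity, read by sulforhodamine B assay, with a stated time of 48 h (a lower number here means a stronger inhibitor, a higher number a weaker inhibitor), compound 1 (`COc1ccc2nc(-c3ccc(N/C=C\C(=O)c4cc(OC)c(OC)c(OC)c4)c(C)c3)sc2c1`) gives 16100 nM and compound 2 (`COc1ccc2nc(-c3ccc(N/C=C\C(=O)c4cc(OC)c(OC)c(OC)c4)cc3)sc2c1`) gives 14100 nM, so the two stand level. Compound 3 (`COc1ccc2nc(-c3ccc(N/C=C\C(=O)c4cc(OC)c(OC)c(OC)c4Br)c(C)c3)sc2c1`) carries bromo in place of hydrogen on an aromatic carbon of compound 1, ortho to a large group (bromo in place of hydrogen on an aromatic carbon). Among the compounds with values here, the only measured step, a 1.1-fold lower number from compound 1 to compound 2 (0.06 log units; within the scatter), lies within the scatter, but it concerns a different place in the molecule and gives only weak guidance. The expected step is therefore a 1.3-fold lower number from compound 1 to compound 3 (0.13 log units; within the scatter), which is none beyond the scatter in this assay. Compound 3 is estimated at 12000 nM, with a range from 2500 nM to 40000 nM.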

Compound 3, half-maximal inhibitory concentration: 13400 nM
Compound 3: middle estimate off by 1.1-fold (0.05 log units), on the low side; the measured number falls inside the stated range.
By their numbers in this assay, from the lowest: compounds 3, 2 and 1 (each within the scatter of the next).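

Placing bromo on this aromatic carbon, ortho to a large group and ortho to a methoxy group, gives a 1.2-fold lower number from compound 1 to compound 3 (0.08 log units; within the scatter) in this assay. Compound 3 therefore stands level with compound 1, so this position takes a bromine atom in place of hydrogen with no change beyond the scatter, something the earlier step at the methyl group could not show. No measurement offered here explains this result. On these data alone, whether a smaller fluoro group, an amine or a carboxylic acid on this carbon would also leave the number level remains open.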